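The compounds below may be only part of what the source reports. "The series", "measured", "known", "first", "only" and "open" are said of these compounds alone.

Three compounds share one core and differ only in the aryl group on the carbonyl carbon. Compound 1 `COc1cc(C(=O)C2Sc3nnc(-c4cc(OC)c(OC)c(OC)c4)n3NC2c2ccco2)cc(OC)c1OC` gives 48300 nM in a functional assay on A549 cells (Homo sapiens) for cytotoxicity, read by MTT assay, with a stated time of 48 h; on this read-out higher numbers stand for weaker inhibition and lower numbers for stronger inhibition; compound 2 `COc1cc(-c2nnc3n2NC(c2ccco2)C(C(=O)c2cccs2)S3)cc(OC)c1OC` gives 78700 nM; compound 3 `COc1cc(-c2nnc3n2NC(c2ccco2)C(C(=O)c2ccccc2)S3)cc(OC)c1OC` gives 33400 nM. Compound 3 sits at the low end of these numbers, with a 1.4-fold lower number from compound 1 to compound 3 (0.16 log units; within the scatter) and a 2.4-fold lower number from compound 2 to compound 3 (0.37 log units; beyond the scatter) marking its distance from the others. Compound 4 `COc1cc(-c2nnc3n2NC(c2ccco2)C(C(=O)c2ccc([N+](=O)[O-])cc2)S3)cc(OC)c1OC` carries nitro in place of hydrogen on an aromatic carbon. Among the measured compounds shown here, the steps that bear on it, a 1.4-fold lower number from compound 1 to compound 3 (0.16 log units; within the scatter) and a 2.4-fold lower number from compound 2 to compound 3 (0.37 log units; beyond the scatter), show that changing the aryl group on the carbonyl carbon moves this assay only modestly, so an added nitro group is expected to give a step of a 1.1-fold lower number from compound 3 to compound 4 (0.05 log units; within the scatter), not beyond the scatter in either direction. Compound 4 is estimated at 30000 nM, expected between 12000 nM and 75000 nM.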

Compound 4, half-maximal inhibitory concentration: > 100000 nM
Compound 4: only a limit was reported; the forecaster's own chance of this, stated with the estimate: 5%; at least 3.3-fold (0.52 log units) between middle value and limit.
By their numbers in this assay, from the lowest: compounds 3, 1 and 2 (each within the scatter of the next, the first and the last beyond it). At a limit, above all of these: compound 4.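

In this assay compound 4 is reported only as a limit of the assay: the limit of > 100000 nM in this assay, at which 1 of the 4 values shown sits. Among the compounds shown here, the aryl group on the carbonyl carbon therefore tolerates less than the earlier compounds suggested, with 4-nitrophenyl giving an at least 2.9-fold higher number from compound 3 to compound 4 (0.47 log units; beyond the scatter) and an at least 2.0-fold higher number from compound 1 to compound 4 (0.31 log units; beyond the scatter). The floor of the third comparison stays within the scatter, at an at least 1.2-fold higher number from compound 2 to compound 4 (0.10 log units; that floor lies within the scatter), so compound 4 is not separated from compound 2 by its printed step.

Going by these compounds, the full size of the nitro step stays unknown. Also open, on these data alone, is whether an amine or a carboxylic acid at the same place on the phenyl ring would read near compound 3 or near compound 4.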